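A few compounds are considered here, and "the series" means these few. Any claim that something is new, unique, unknown or untested is made for them only; others in the source may bear on it.

Working notes on the series. Among the compounds with values here, compound 1 `COc1ccc(CCOC(=O)c2oc3cc(-c4ccccc4)cc(O)c3c2C)cc1` is the only compound with a number: in a functional assay on WI-38 VA13 cells (Homo sapiens) for cytotoxicity (a lower number here means that less compound is needed, a higher number that more compound is needed for the effect), compound 1 gives 0.02 ug/mL. Compound 2 `Cc1c(C(=O)c2cnc3ccccc3c2)oc2cc(-c3ccccc3)cc(O)c12` carries a limit rather than a number, and in this assay compound 2 gives > 4 ug/mL, as recorded in the limit of > 4 ug/mL in this assay, at which 1 of the 2 values shown sits. Compound 3 `Cc1ncsc1CCOC(=O)c1oc2cc(-c3ccccc3)cc(O)c2c1C` is not yet measured. It differs from compound 1 by 4-methyl-1,3-thiazol-5-yl in place of 4-methoxyphenyl on a saturated chain carbon, two bonds along the chain from an oxygen next to a carbonyl group. The ester chain of compound 1 is kept. Within the data shown here, with no comparable step measured, a small change beyond the scatter toward a weaker value is expected, a 2.5-fold higher number from compound 1 to compound 3 (0.40 log units; beyond the scatter). For compound 3 in this assay the estimate is 0.05 ug/mL, within 0.01 ug/mL to 0.3 ug/mL.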

Compound 3, half-maximal effective concentration: 0.055 ug/mL
Compound 3: the middle estimate sits 1.1-fold (0.04 log units) below what was measured, within the range that was stated.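

In this assay, within the data shown here, 4-methyl-1,3-thiazol-5-yl in place of 4-methoxyphenyl gives the first readable step at this saturated chain carbon: a 2.8-fold higher number from compound 1 to compound 3 (0.44 log units; beyond the scatter). The position therefore tolerates a five-membered aromatic ring with 2 hetero atoms in place of a six-membered aromatic ring of carbon only, with a modest change in the number. Nothing measured in the series bears on the reason for this step.

Still open, on these data alone, is how an amine or a carboxylic acid in place of the ring would read out at this carbon. Also open, as far as these compounds go, is whether a longer chain carrying either ring would shift the number.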